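Replacing bromo with nitro: what to expect for compound 4

The source may report more compounds than this note shows. Statements on the series, on what has been measured and on what is new or still open speak of the compounds shown alone.

Within the data shown here, the three compounds measured so far share one core and differ only in a single group on an outer ring. Compound 1 `O=C(CSc1nc(Nc2ccccc2)c2ccccc2n1)Nc1cccc(F)c1` carries fluoro, and in a functional assay on MDA-MB-231 cells (Homo sapiens) for inhibition, read by MTT assay, with a stated time of 72 h (on this read-out lower numbers stand for stronger inhibition and higher numbers for weaker inhibition), compound 1 reaches only the assay limit of > 50000 nM, which is a limit and not a number. Compound 2 `O=C(CSc1nc(Nc2ccccc2)c2ccccc2n1)Nc1cccc(Cl)c1` carries chloro, and in this assay compound 2 gives 16500 nM. Compound 3 `O=C(CSc1nc(Nc2ccccc2)c2ccccc2n1)Nc1cccc(Br)c1` carries bromo, and in this assay compound 3 gives 17500 nM. Among the two real numbers compound 3 holds the higher one, but the step of a 1.1-fold higher number from compound 2 to compound 3 (0.03 log units; within the scatter) lies within the scatter, so the two cannot be told apart. Two steps did move the number beyond the scatter: an at least 3.0-fold lower number from compound 1 to compound 2 (0.48 log units; beyond the scatter) and an at least 2.8-fold lower number from compound 1 to compound 3 (0.45 log units; beyond the scatter), each starting from a value that is only a limit (the limit of > 50000 nM in this assay, at which 1 of the 3 values shown sits).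

Compound 4 `O=C(CSc1nc(Nc2ccccc2)c2ccccc2n1)Nc1cccc([N+](=O)[O-])c1` is not yet measured and differs from compound 3 in one place: nitro in place of bromo on an aromatic carbon. No measured step involves nitro, so the shown steps give no direct guide; they only show that chloro and bromo behave alike. I therefore expect the step of a 1.1-fold higher number from compound 3 to compound 4 (0.06 log units; within the scatter) for compound 4 to stay within the scatter. My estimate for compound 4 is 20000 nM, with a range from 6000 nM to 60000 nM.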

Compound 4, half-maximal inhibitory concentration: 33000 nM
Compound 4: the middle estimate sits 1.7-fold (0.22 log units) below what was measured, and the stated range covers the measured number.
By their numbers in this assay, from the lowest: compounds 2, 3 and 4 (each within the scatter of the next). At a limit, above all of these: compound 1.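

In this assay, nitro, with three heavy atoms and two hydrogen-bond acceptors, takes the place of a single bromine or chlorine and the numbers stay within the scatter: a 1.9-fold higher number from compound 3 to compound 4 (0.28 log units; within the scatter) and a 2.0-fold higher number from compound 2 to compound 4 (0.30 log units; within the scatter). Among these compounds, the first group here that is not a halogen therefore sits with compound 2 and compound 3 rather than apart from them, and these three compounds cannot be ranked. The comparison with fluoro gives an at least 1.5-fold lower number from compound 1 to compound 4 (0.18 log units; that floor lies within the scatter), which starts from a limit of the assay and not a number, so compound 4 cannot be set apart from compound 1: the limit of > 50000 nM in this assay, at which 1 of the 4 values shown sits.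

The compounds shown leave open whether an amine, a carboxylic acid or a methoxy group at this place on the ring would bring the number clearly below those of compound 2 and compound 3. They also leave open whether chloro, bromo and nitro would stay as close together at other places on this ring or on the other outer ring of the shared core.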